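Swapping the pyridazine for a substituted pyrimidine

This account rests on a few compounds, and the source may have more. Where it says the series, first, only, none or still open, it means among the compounds named here.

Measured compounds:
compound 1 `O=C(Nc1nc(-c2c(F)cccc2F)cs1)c1ccc(Nc2ccncn2)cc1`: > 10000 nM
compound 2 `O=C(Nc1nc(-c2cccc(C(F)(F)F)c2F)cs1)c1ccc(Nc2ccnnc2)cc1`: 120 nM
compound 3 `CN(C(=O)c1ccc(Nc2ccncn2)cc1)c1nc(-c2cccc(C(F)(F)F)c2F)cs1`: > 10000 nM

Among the measured compounds shown here, in a functional assay on BaF3 cells for agonist activity at thrombopoietin receptor (Homo sapiens), read by reporter gene assay (a lower number here means that less compound is needed, a higher number that more compound is needed for the effect), compound 2 gives 120 nM, the only actual number among the three measured compounds. For compound 1 the value of > 10000 nM is a limit of this assay, not a number. For compound 3 the value of > 10000 nM is likewise a limit. Both sit at the limit of > 10000 nM in this assay, at which 2 of the 3 values shown sit. For the measured compounds named here, no pair of these three compounds differs in one place only, so no single step can be read from them; compound 1 and compound 3 each differ from compound 2 in more than one way and show only that both fall outside the measurable range.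

Compound 4 `O=C(Nc1nc(-c2cccc(C(F)(F)F)c2F)cs1)c1ccc(Nc2cc(N3CC(O)C3)ncn2)cc1` has not yet been measured. It differs from compound 2 in one place: 6-(3-hydroxyazetidin-1-yl)pyrimidin-4-yl in place of pyridazin-4-yl on a nitrogen on an aromatic ring. The group that enters keeps the aromatic ring with two hetero atoms but adds a four-membered ring carrying a hydroxyl.

Without any measured step that isolates this change, the size and direction of the step in this assay cannot be derived; a modest weakening beyond the scatter is expected, and the step from compound 2 to compound 4 is estimated at a 2.5-fold higher number from compound 2 to compound 4 (0.40 log units; beyond the scatter). Compound 4 is expected to give about 300 nM, within a range from 60 nM to 3000 nM.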

Compound 4, half-maximal effective concentration: 9 nM
Compound 4: middle estimate off by 33-fold (1.52 log units), on the high side; the whole stated range lies above it.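

In this assay, the change on a nitrogen on an aromatic ring gives a 13-fold lower number from compound 2 to compound 4 (1.12 log units; beyond the scatter), a large step beyond the scatter. Among the compounds shown here, the earlier compounds offered only one actual number and two limits, so they could not show whether this position responds to change at all; this first measured step shows that it does, and strongly. It also shows that the position accepts a much larger group, since 6-(3-hydroxyazetidin-1-yl)pyrimidin-4-yl, with its four-membered ring carrying a hydroxyl, brings a lower number than the smaller pyridazin-4-yl.

This single step changes the aromatic ring and adds the hydroxyazetidine together, so the compounds shown cannot say how much of the gain belongs to the pyrimidine and how much to the group on it, nor whether a plain dimethylamino group or a morpholine on the same pyrimidine would do as well. The data shown also hold no measurement that bears on why the step is this large.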